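Replacing hydroxy with aminoamino: what compound 3 may show

This account rests on a few compounds, and the source may have more. Where it says the series, first, only, none or still open, it means among the compounds named here.

Compound 1 `N#Cc1c(O)nc(SCc2nc3ccccc3[nH]2)nc1-c1ccccc1` gives 2.55 nM
Compound 2 `N#Cc1c(Cl)nc(SCc2nc3ccccc3[nH]2)nc1-c1ccccc1` gives 4.46 nM

In a functional assay on HL-60 cells (Homo sapiens) for cytotoxicity, read by MTT assay, with a stated time of 3 days (a higher number here means a weaker inhibitor, a lower number a stronger inhibitor), compound 1 has only compound 2 for comparison, and the two lie within the scatter of each other. Compound 3 `N#Cc1c(NN)nc(SCc2nc3ccccc3[nH]2)nc1-c1ccccc1`, not yet measured, shows aminoamino in place of hydroxy on an aromatic carbon on the carbon next to the ring nitrogen and ortho to a cyano group. Within the data shown here, the one step bearing on this carbon, chloro in place of hydroxy, is a 1.7-fold higher number from compound 1 to compound 2 (0.24 log units; within the scatter). Among the measured compounds shown here, no measured compound carries aminoamino, so the expectation is uncertain, but no step beyond the scatter is expected. The expected value for compound 3 is 4 nM, with a range from 1 nM to 15 nM. This estimated step is a 1.6-fold higher number from compound 1 to compound 3 (0.20 log units; within the scatter).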

Compound 3, half-maximal inhibitory concentration: 11.9 nM
The estimate for compound 3 lay 3.0-fold (0.47 log units) below the measured number, and the stated range covers the measured number.
By their numbers in this assay, from the lowest: compounds 1 and 2 (each within the scatter of the next); then compound 3.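

In this assay, this carbon turns out to be sensitive to the group it carries: aminoamino stands apart from hydroxy (a 4.7-fold higher number from compound 1 to compound 3 (0.67 log units; beyond the scatter)) and from chloro (a 2.7-fold higher number from compound 2 to compound 3 (0.43 log units; beyond the scatter)). Hydroxy and chloro had stayed within the scatter of each other, so the first step beyond the scatter at this position comes with aminoamino, and it remains modest. The compounds shown leave open whether a plain amine or a methoxy group here would stay with hydroxy and chloro or go with aminoamino. Nothing available accounts for the difference.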